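Replacing pyridin-3-yl with amino on compound 2

The source may hold more compounds than are shown below. What is called first, only, known or untested is meant among the compounds shown, and "the series" means these compounds.

Three related compounds have been taken through an ADME assay on BJ cells (Homo sapiens) for cytotoxicity, with a stated time of 72 h; on this read-out lower numbers stand for an effect already at smaller amounts and higher numbers for an effect only at larger amounts of compound. For compound 1 `Nc1nc(-c2ccccn2)nn1-c1ncnc2cc(N3CCNCC3)c([N+](=O)[O-])cc12` there is no result, and its entry reads "not determined" (no result reported). Compound 2 `COc1cc2ncnc(-n3nc(-c4cccnc4)nc3N)c2cc1OC` gives > 71000 nM, which is a limit and not a measured number. Compound 3 `COCCOc1cc2ncnc(-n3nc(-c4ccccn4)nc3N)c2cc1OCCOC` gives > 27000 nM, which is also a limit. Within the data shown here, compound 2 therefore stands at a limit, and there is no step between two measured compounds to learn from.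

Compound 4 `COc1cc2ncnc(-n3nc(N)nc3N)c2cc1OC` changes compound 2 in one place: amino in place of pyridin-3-yl on an aromatic carbon. An amino group takes the place of pyridin-3-yl on an aromatic carbon, while the rest of the structure stays the same.

The expectation rests on compound 2, whose > 71000 nM is a limit, and no step beyond the usual scatter is expected in this assay. The estimated change is a step that the limit leaves unreadable from compound 2 to compound 4. Compound 4 is expected at 85000 nM, with an estimated range from 35000 nM to 170000 nM.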

Compound 4, half-maximal effective concentration: > 33000 nM
Compound 4: no number, only a limit; the forecaster's own chance of this, stated with the estimate: 80%; the middle value does not contradict the limit.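

Compound 2 and compound 4 each give only a limit and not a number, so the step for amino in place of pyridin-3-yl on an aromatic carbon cannot be read. The compounds shown leave open whether this swap changes cytotoxicity at all.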